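The compounds below may be only part of what the source reports. "The series", "measured", "known", "first", "only" and "open" are said of these compounds alone.

Of the compounds shown here, three that share one core have been measured in a functional assay on CHO-K1 cells for antagonist activity at adenosine receptor A1 (Homo sapiens), read by a beta-galactosidase reporter and cAMP accumulation, with stated times of 15 min and 6 h; on this read-out lower numbers stand for stronger inhibition and higher numbers for weaker inhibition. Compound 1 `CCc1ccc(-c2nc(N)c3cc(Cc4ccccc4)sc3n2)o1` gives 223 nM, compound 2 `Nc1nc(C2CCCO2)nc2sc(Cc3ccccc3)cc12` gives 2950 nM, and compound 3 `Cc1csc(-c2nc(N)c3cc(Cc4ccccc4)sc3n2)n1` gives 1490 nM. Compound 3 therefore stands second highest of the three numbers: a 6.7-fold higher number from compound 1 to compound 3 (0.82 log units; beyond the scatter), whereas a 2.0-fold lower number from compound 2 to compound 3 (0.30 log units; within the scatter). Compound 4 `Nc1nc(-c2ccccc2)nc2sc(Cc3ccccc3)cc12` is not yet measured; it differs from compound 3 in one place, (phenyl in place of 4-methyl-1,3-thiazol-2-yl on an aromatic carbon). Within the data shown here, the steps that bear on this position are a 13-fold higher number from compound 1 to compound 2 (1.12 log units; beyond the scatter) and a 6.7-fold higher number from compound 1 to compound 3 (0.82 log units; beyond the scatter), both starting from the group found in compound 1, and neither involves a phenyl group, so the direction of the coming change is open. A step of a 1.5-fold lower number from compound 3 to compound 4 (0.17 log units; within the scatter) in this assay is expected, with no firm direction. For compound 4 the estimate is 1000 nM, with a range from 250 nM to 4000 nM.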

Compound 4, inhibition constant: 151 nM
Compound 4: middle estimate off by 6.6-fold (0.82 log units), on the high side; the whole stated range lies above it.
By their numbers in this assay, from the lowest: compounds 4 and 1 (each within the scatter of the next); then compounds 3 and 2 (each within the scatter of the next).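

In this assay, a plain phenyl on this carbon between two ring nitrogen atoms gives a much lower number than either 4-methyl-1,3-thiazol-2-yl (a 9.9-fold lower number from compound 3 to compound 4 (0.99 log units; beyond the scatter)) or oxolan-2-yl (a 20-fold lower number from compound 2 to compound 4 (1.29 log units; beyond the scatter)), while it cannot be told apart from 5-ethylfuran-2-yl (a 1.5-fold lower number from compound 1 to compound 4 (0.17 log units; within the scatter)). An aromatic ring alone does not settle the number, since compound 3 also carries one and stays high. No measurement at hand explains these differences.

Still open, going by these compounds, is whether a methoxy group or chlorine on the phenyl, or a piperidine in its place, would keep this level.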